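This account rests on a few compounds, and the source may have more. Where it says the series, first, only, none or still open, it means among the compounds named here.

Compound 1: `Cc1ccc(-c2noc(CCCCCCC(=O)NO)n2)cc1`, 5390 nM.
Compound 2: `COc1ccc(-c2noc(CCCCCCC(=O)NO)n2)cc1`, > 10000 nM.

In an assay on isolated protein for inhibition of histone deacetylase 8 (Homo sapiens), read by fluorescence, with a stated time of 10 min (a higher number here means a weaker inhibitor, a lower number a stronger inhibitor), compound 1 gives 5390 nM. Compound 2 sits at the limit of > 10000 nM in this assay, at which 1 of the 2 values shown sits, so its value is a limit of the assay rather than a number. Among the compounds with values here, the only measured step is an at least 1.8-fold higher number from compound 1 to compound 2 (0.26 log units; that floor lies within the scatter). Compound 3, `O=C(CCCCCCc1nc(-c2ccc(C(F)(F)F)cc2)no1)NO`, carries trifluoromethyl in place of methoxy on an aromatic carbon. Neither measured compound bears a trifluoromethyl group, so the measured step gives no direction for this change. In this assay compound 3 is expected near 10000 nM, within a range from 3000 nM to 30000 nM. The step of a number no higher from compound 2 to compound 3 (the limit leaves the size open) is expected to stay within the scatter.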

Compound 3, half-maximal inhibitory concentration: > 10000 nM
Compound 3 was reported as a limit; the forecaster's own chance of this, stated with the estimate: 50%; the middle value lies on the limit itself.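

In this assay compound 3 gives > 10000 nM, which is a limit and not a number. Trifluoromethyl in place of methyl gives an at least 1.8-fold higher number from compound 1 to compound 3 (0.26 log units; that floor lies within the scatter), and the step from methoxy to trifluoromethyl cannot be read. Of the three compounds, only the methyl compound 1 now has a readable number, and a second replacement at this aromatic carbon ends at the same limit: the limit of > 10000 nM in this assay, at which 2 of the 3 values shown sit.

Open, on these data alone, is how far compound 2 and compound 3 lie past that limit. Also open, as far as these compounds go, is whether an amine or a chlorine atom on this carbon would give a readable number.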